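Butylamino for diethylamino at the benzylic amine of a chloro-biaryl

This account rests on a few compounds, and the source may have more. Where it says the series, first, only, none or still open, it means among the compounds named here.

Measured compounds:
compound 1 `COc1ccccc1-c1cc(CN(C)C)ccc1Cl`, 1150 nM; 1100 nM (2 entries)
compound 2 `CCN(CC)Cc1ccc(Cl)c(-c2ccccc2OC)c1`, "not active" (no number reported)

In a functional assay on HEK293 cells for agonist activity at 5-hydroxytryptamine receptor 7 (Homo sapiens), read by cAMP accumulation, with a stated time of 30 min (on this read-out higher numbers stand for an effect only at larger amounts of compound and lower numbers for an effect already at smaller amounts), compound 1 gives 1150 nM; 1100 nM (2 entries) across its repeats (the several entries of compound 1 in this assay, 1150 nM; 1100 nM (2 entries)). Compound 2 `CCN(CC)Cc1ccc(Cl)c(-c2ccccc2OC)c1`, in contrast, is reported in this assay only as "not active" (no number reported); it carries no single number, and one further entry for it is likewise without a number. Compound 2 therefore stands at the inactive end of what is shown, and no step between two measured values can be calculated from it.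

Compound 3 `CCCCNCc1ccc(Cl)c(-c2ccccc2OC)c1` has not yet been measured in this assay. It differs from compound 2 by butylamino in place of diethylamino on a saturated chain carbon bound to an aromatic carbon. With only an inactive report on compound 2, no step size can be computed; a move toward activity within a small margin beyond the scatter is expected rather than a large one. Compound 3 is expected to give 4000 nM, estimated between 600 nM and 25000 nM, with a real chance that only a limit is reported.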

Compound 3, half-maximal effective concentration: "not active" (no number reported)
Compound 3: no number reported; there is nothing to compare the estimate with.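

In this assay, within the data shown here, compound 3, like compound 2, is reported only as not active, so no step between them can be read. The compounds shown leave open whether butylamino and diethylamino differ at all at this place, and nothing shown accounts for either report.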